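Acid to dimethylamide at the carbonyl carbon: working notes

The source may hold more compounds than are shown below. What is called first, only, known or untested is meant among the compounds shown, and "the series" means these compounds.

Measured compounds:
compound 1 `CC(=O)O[C@]1(C)/C=C/C(=O)/C(CO)=C\C[C@](C)(CCC=C(C)C)/C=C/[C@H]1OC(=O)C=C(C)C`: 3150 nM
compound 2 `CC(C)=CCC[C@]1(C)/C=C/[C@@H](OC(=O)C=C(C)C)[C@](C)(O)/C=C/C(=O)/C(C(=O)O)=C\C1`: > 10000 nM
compound 3 `CC(C)=CCC[C@](C)(/C=C/[C@@H](OC(=O)C=C(C)C)[C@](C)(O)/C=C/C(=O)/C=C/N(C)C)CC=O`: 11200 nM

In a functional assay on A549 cells (Homo sapiens) for antiproliferative activity, read by MTT assay, with a stated time of 48 h (on this read-out higher numbers stand for weaker inhibition and lower numbers for stronger inhibition), compound 1 gives 3150 nM. In this assay compound 2 gives only a limit, > 10000 nM, and no number. In this assay compound 3 gives 11200 nM. Compound 2 therefore stands at the limit of > 10000 nM in this assay, at which 1 of the 3 values shown sits, the weak end of what the three values show, with no number of its own to compare against compound 1 or compound 3.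

Compound 4 `CC(C)=CCC[C@]1(C)/C=C/[C@@H](OC(=O)C=C(C)C)[C@](C)(O)/C=C/C(=O)/C(C(=O)N(C)C)=C\C1` differs from compound 2 in one place: dimethylamino in place of hydroxy on a carbonyl carbon.

Within the data shown here, no step between measured compounds is available in this assay, so the size of this change cannot be read from the series itself. Compound 3, which also carries a dimethylamino group though on a different carbon, gives 11200 nM, toward the weak end of what the three values show. On that basis the expectation for compound 4 is a step from the limit of compound 2 toward a measurable number, but not far beyond the scatter. The expected step is an at least 1.2-fold lower number from compound 2 to compound 4 (0.09 log units; that floor lies within the scatter). Compound 4 is estimated at 8000 nM, with a range from 2500 nM to 25000 nM.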

Compound 4, half-maximal inhibitory concentration: 2700 nM
Compound 4: the middle estimate sits 3.0-fold (0.47 log units) above what was measured, and the stated range covers the measured number.
By their numbers in this assay, from the lowest: compounds 4 and 1 (each within the scatter of the next); then compound 3.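

In this assay compound 2 gives > 10000 nM, which is a limit of the assay and not a number. Among these compounds, replacing hydroxy with dimethylamino on a carbonyl carbon whose other neighbour is a double-bonded ring carbon, which reads as carboxy to dimethylcarbamoyl, gives an at least 3.7-fold lower number from compound 2 to compound 4 (0.56 log units; beyond the scatter); this is the first step that can be read, and it shows that activity at this position responds to what the carbonyl carbon carries. The step is only a floor and its full size stays unknown, because compound 2 has no number of its own: the limit of > 10000 nM in this assay, at which 1 of the 4 values shown sits.

As far as these compounds go, whether this step is particular to dimethylcarbamoyl or would follow from other replacements of carboxy remains open, and a methyl ester or a primary carboxamide on the same carbonyl carbon would help separate those two readings. From the compounds shown here alone, with one step on one cell line, it also remains open whether the same change would give a step of similar size on the other compounds or in other cell lines.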